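Nitro on the aryl at the saturated carbon: compound 4

A few compounds are considered here, and "the series" means these few. Any claim that something is new, unique, unknown or untested is made for them only; others in the source may bear on it.

Measured so far:
- compound 3 `CCOc1ccc2c(c1)OC(c1ccccc1)C(c1ccccc1)C2=O`; in a functional assay on HL-60 cells (Homo sapiens) for cytotoxicity, read by MTT assay, with a stated time of 5 days (a higher number here means that more compound is tolerated, a lower number that less compound is tolerated), compound 3 gives > 2500000 nM, a limit of the assay and not a number.
- compound 1 `COc1ccc2c(c1)OC(c1cccc([N+](=O)[O-])c1)C(c1ccccc1)C2=O`; in this assay compound 1 gives > 2500000 nM, also a limit of the assay rather than a number.
- compound 2 `COc1ccc2c(c1)OC(c1ccc(Cl)cc1)C(c1ccccc1)C2=O`; in this assay compound 2 gives 2410000 nM.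

Compound 3 thus stands only at a limit: no number is known for it, and the same holds for compound 1, as summarised by the limit of > 2500000 nM in this assay, at which 2 of the 3 values shown sit. Going by the values given here, the one measured number, that of compound 2, is of the same size as that limit.

The unmeasured compound 4 `CCOc1ccc2c(c1)OC(c1cccc([N+](=O)[O-])c1)C(c1ccccc1)C2=O` differs from compound 3 by nitro in place of hydrogen on an aromatic carbon; cut one bond further out, the change reads phenyl to 3-nitrophenyl. Among the compounds with values here, the only measured step that touches the same part of the core is an at least 1.0-fold lower number from compound 1 to compound 2 (0.01 log units; that floor lies within the scatter), in which the 3-nitrophenyl compound sits at the limit and the 4-chlorophenyl compound gives a number of the same size; that step is within the scatter. Within the data shown here, nothing among the measured compounds points to a change beyond the scatter on introducing the nitro group, and compound 4 is therefore expected to sit where compound 3 sits, most likely again at the limit.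

The expected step is a number no higher from compound 3 to compound 4 (the limit leaves the size open). For compound 4 the estimate is 2500000 nM, with a range from 1200000 nM to 5000000 nM.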

Compound 4, half-maximal cytotoxic concentration: > 2500000 nM
Compound 4 gave a limit, no number; the forecaster's own chance of this, stated with the estimate: 70%; the middle value lies on the limit itself.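

In this assay compound 4 gives > 2500000 nM, a limit of the assay and not a number. Compound 3 and compound 1 also stand at limits, so neither step to compound 4 can be read. The compounds shown leave open whether nitro in place of hydrogen changes the tolerated concentration at all, with most values at one limit: the limit of > 2500000 nM in this assay, at which 3 of the 4 values shown sit.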